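Methoxyphenyl Amide Replaces Bromophenyl in a Benzimidazole Indazole Series

This account rests on a few compounds, and the source may have more. Where it says the series, first, only, none or still open, it means among the compounds named here.

Compound 1 `CN(C(=O)c1ccc(F)cc1)c1ccc2[nH]c(-c3n[nH]c4ccccc34)cc2n1`: 7220 nM
Compound 2 `CN(C(=O)c1ccc(Br)cc1)c1ccc2[nH]c(-c3n[nH]c4ccccc34)cc2n1`: 1780 nM

Among the measured compounds shown here, in a functional assay on KB cells (Homo sapiens) for antiproliferative activity, read by MTT assay, with a stated time of 72 h (on this read-out lower numbers stand for stronger inhibition and higher numbers for weaker inhibition), compound 2 gives the lowest of the two numbers, with compound 1 the only neighbour. For the measured compounds named here, the one measured step, a 4.1-fold lower number from compound 1 to compound 2 (0.61 log units; beyond the scatter), shows that exchanging a halogen on the aryl amide moves the read-out beyond the scatter. Compound 3 `COc1cccc(C(=O)N(C)c2ccc3[nH]c(-c4n[nH]c5ccccc45)cc3n2)c1` carries 3-methoxyphenyl in place of 4-bromophenyl on a carbonyl carbon. Going by the values given here, no measured step covers this exchange, so the expectation rests only on the sign that the aryl group matters, and compound 3 is expected to return a higher number, with the step of a 2.2-fold higher number from compound 2 to compound 3 (0.35 log units; beyond the scatter) estimated. Compound 3 is estimated at 4000 nM, within 1500 nM to 12000 nM.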

Compound 3, half-maximal inhibitory concentration: 9010 nM
Compound 3: middle estimate off by 2.3-fold (0.35 log units), on the low side, and the stated range covers the measured number.
By their numbers in this assay, from the lowest: compound 2; then compounds 1 and 3 (each within the scatter of the next).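

In this assay the exchange of 4-bromophenyl for 3-methoxyphenyl on the carbonyl carbon gives a 5.1-fold higher number from compound 2 to compound 3 (0.70 log units; beyond the scatter) and so does not keep the low number of the bromo amide. Set against the fluoro amide, the same group gives a 1.2-fold higher number from compound 1 to compound 3 (0.10 log units; within the scatter) and leaves 3-methoxyphenyl and 4-fluorophenyl indistinguishable here, with 4-bromophenyl alone standing apart among the three. Nothing available explains this difference.

The exchange alters both the substituent and its ring position at once, so the compounds shown cannot separate these two changes. Going by these compounds, how 4-methoxyphenyl or 3-bromophenyl would read remains open.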